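Trimethoxyphenyl Amide in Place of Styryl Amide: Expected Cytotoxicity

A few compounds are considered here, and "the series" means these few. Any claim that something is new, unique, unknown or untested is made for them only; others in the source may bear on it.

Three compounds have been measured in a functional assay on Ehrlich cells (Mus musculus) for cytotoxicity, read by trypan blue exclusion, with a stated time of 2 h, tested at 10 ug/mL; a higher number here means a stronger effect of the compound at the concentration tested, a lower number a weaker effect:
Compound 1, `CC(Cl)CC(=O)NC1=C(C#N)C(c2ccc(Cl)cc2Cl)C2=C(CCCC2=O)N1c1ccc(S(N)(=O)=O)cc1`, gives 20%.
Compound 2, `N#CC1=C(NC(=O)c2ccccc2)N(c2ccc(S(N)(=O)=O)cc2)C2=C(C(=O)CCC2)C1c1ccc(Cl)cc1Cl`, gives 50%.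
Compound 3, `N#CC1=C(NC(=O)/C=C/c2ccccc2)N(c2ccc(S(N)(=O)=O)cc2)C2=C(C(=O)CCC2)C1c1ccc(Cl)cc1Cl`, gives 30%.

Compound 3 stands second highest of the three; its nearest neighbour, compound 1, lies within the scatter of it, while compound 2 sits higher, beyond the scatter. Compound 4, `COc1cc(C(=O)NC2=C(C#N)C(c3ccc(Cl)cc3Cl)C3=C(CCCC3=O)N2c2ccc(S(N)(=O)=O)cc2)cc(OC)c1OC`, is not yet measured. 3,4,5-trimethoxyphenyl in place of 2-phenylethenyl on a carbonyl carbon The step that bears most directly on this exchange is a number 20 percentage points lower from compound 2 to compound 3 (beyond the scatter), where a six-membered aromatic ring of carbon only on the carbonyl carbon gave way to 2-phenylethenyl; compound 4 again carries such a ring on that carbon. a number 30 percentage points higher from compound 1 to compound 2 (beyond the scatter) and a number 10 percentage points higher from compound 1 to compound 3 (within the scatter) point the same way. An upward step beyond the scatter is therefore expected, a number 10 percentage points higher from compound 3 to compound 4 (within the scatter). Compound 4 is expected to give 40%, estimated between 20% and 60%.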

Compound 4, a percentage reported as activity, at one concentration (the size of the read-out at that concentration, not a potency): 0%
The estimate for compound 4 lay 40 percentage points above the measured number, and the stated range ends above it.
By their numbers in this assay, from the lowest: compound 4; then compounds 1 and 3 (each within the scatter of the next); then compound 2.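

On this carbonyl carbon, a six-membered aromatic ring of carbon only does not by itself carry the effect: 3,4,5-trimethoxyphenyl in place of phenyl gives a number 50 percentage points lower from compound 2 to compound 4 (beyond the scatter) in this assay and shows that what the ring carries counts here. With a number 30 percentage points lower from compound 3 to compound 4 (beyond the scatter) and a number 20 percentage points lower from compound 1 to compound 4 (beyond the scatter) as well, compound 4 is the weakest of the four. Nothing available explains this drop.

Still open, on these data alone, is whether all three methoxy groups are needed for the loss. Also open, as far as these compounds go, is how a phenyl ring carrying an amine or a carboxylic acid would behave at this position.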